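The compounds below may be only part of what the source reports. "The series", "measured", "known", "first", "only" and "open" are said of these compounds alone.

Working notes on the series

Compound 1 `CC(C)c1c(Cc2c(Cl)cccc2Cl)nc(SCC(=O)c2ccccc2)[nH]c1=O` and compound 2 `CC(C)c1c(Cc2c(Cl)cccc2Cl)nc(SCC(=O)c2ccc(F)cc2)[nH]c1=O` share one core. In an ADME assay on MT4 cells (Homo sapiens) for cytotoxicity, read by MTT assay (a lower number here means that less compound is tolerated, a higher number that more compound is tolerated), compound 1 gives > 56000 nM, which is a limit of the assay rather than a number. Compound 2 gives > 54000 nM in this assay, again a limit. The change between them, (fluoro in place of hydrogen on an aromatic carbon), yields a step that the two limits leave unreadable from compound 1 to compound 2.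

Compound 3 `CCc1c(Cc2c(F)cccc2Cl)nc(SCC(=O)c2ccccc2)[nH]c1=O` carries a second core; the difference between the two cores is not broken down here. In this assay compound 3 gives > 12000 nM, a limit. Compound 4 `CCc1c(Cc2c(F)cccc2Cl)nc(SCC(=O)c2ccc(F)cc2)[nH]c1=O` is not yet measured and differs from compound 3 by fluoro in place of hydrogen on an aromatic carbon, the same change as from compound 1 to compound 2.

For compound 4 the expected step is a step that the limit leaves unreadable from compound 3 to compound 4, resting on compound 1 to compound 2 giving a step that the two limits leave unreadable from compound 1 to compound 2. Compound 4 is therefore estimated at 30000 nM, between 12000 nM and 70000 nM.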

Compound 4, half-maximal cytotoxic concentration: > 57000 nM
Compound 4: only a limit was reported; the forecaster's own chance of this, stated with the estimate: 80%; middle value at least 1.9-fold (0.27 log units) away from the limit.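

Compound 3 and compound 4 both stand as limits in this assay, so no step can be read between them. Going by these compounds, whether fluoro in place of hydrogen shifts the tolerated concentration in either pair stays open.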